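Aryl hydrazone variation on a shared ribose-bearing core

This account rests on a few compounds, and the source may have more. Where it says the series, first, only, none or still open, it means among the compounds named here.

Three hydrazones built on one shared core have been measured in an assay on CHO-K1 cells for displacement of a labelled ligand from adenosine receptor A1 (Homo sapiens), read by scintillation counting, with a stated time of 60 min; a lower number here means a stronger inhibitor, a higher number a weaker inhibitor. Compound 1 `Nc1nc(N/N=C/c2cccnc2Cl)nc2c1ncn2[C@@H]1O[C@H](CO)[C@@H](O)[C@H]1O` gives 4.6 nM, compound 2 `Nc1nc(N/N=C/c2ccc(Br)cn2)nc2c1ncn2[C@@H]1O[C@H](CO)[C@@H](O)[C@H]1O` gives 4.7 nM, and compound 3 `N#Cc1ccccc1/C=N/Nc1nc(N)c2ncn([C@@H]3O[C@H](CO)[C@@H](O)[C@H]3O)c2n1` gives 2.9 nM. None of the three is separated from another beyond the scatter: the step of a 1.0-fold higher number from compound 1 to compound 2 (0.01 log units; within the scatter) is flat, and the steps of a 1.6-fold lower number from compound 1 to compound 3 (0.20 log units; within the scatter) and a 1.6-fold lower number from compound 2 to compound 3 (0.21 log units; within the scatter) are likewise small, so compound 3 stands among the others rather than apart from them.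

Compound 4 `CCCOc1ccc(/C=N/Nc2nc(N)c3ncn([C@@H]4O[C@H](CO)[C@@H](O)[C@H]4O)c3n2)cc1` differs from compound 3 in one place: 4-propoxyphenyl in place of 2-cyanophenyl on a carbon with a double bond to nitrogen. The measured steps that bear on this are the three exchanges of the aromatic ring on the same carbon, and each of them stayed within the scatter. Among the measured compounds shown here, no measured step speaks to the 4-propoxyphenyl group itself. On that basis the expected step in this assay is a 1.6-fold higher number from compound 3 to compound 4 (0.19 log units; within the scatter), with no direction beyond the scatter. Compound 4 is therefore estimated at 4.5 nM, with a range from 1.5 nM to 14 nM.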

Compound 4, inhibition constant: > 10000 nM
Compound 4 gave a limit, no number (the forecaster's own chance of this, stated with the estimate: 2%); middle value at least 2200-fold (3.34 log units) from the limit.
By their numbers in this assay, from the lowest: compounds 3, 1 and 2 (each within the scatter of the next). At a limit, above all of these: compound 4.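

In this assay compound 4 stands at a limit of the assay, not at a number: the limit of > 10000 nM in this assay, at which 1 of the 4 values shown sits. Among the compounds shown here, the earlier exchanges of the aromatic ring on the carbon with a double bond to nitrogen all stayed within the scatter, but this change gives the first large steps at this position: an at least 3400-fold higher number from compound 3 to compound 4 (3.53 log units; beyond the scatter), an at least 2100-fold higher number from compound 2 to compound 4 (3.32 log units; beyond the scatter) and an at least 2100-fold higher number from compound 1 to compound 4 (3.33 log units; beyond the scatter). From the compounds shown here alone, the flat picture among 2-cyanophenyl, 5-bromopyridin-2-yl and 2-chloropyridin-3-yl therefore does not extend to every aromatic group on this carbon, and the true size of these steps remains unknown beyond their lower bounds.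

The compounds shown leave open whether the propyl chain of the ether or the oxygen on the ring goes with this change. A 4-methoxyphenyl, 4-hydroxyphenyl or 4-propylphenyl group would bear on that question.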